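A few compounds are considered here, and "the series" means these few. Any claim that something is new, unique, unknown or untested is made for them only; others in the source may bear on it.

Of the compounds shown here, three have been tested in a functional assay on ileum for antagonist activity at Substance-P receptor (Cavia porcellus); on this read-out higher numbers stand for weaker inhibition and lower numbers for stronger inhibition. Compound 1 `CN(Cc1cc(C(F)(F)F)cc(C(F)(F)F)c1)C(=O)c1cccnc1-c1ccccc1` gives 151 nM in this assay, compound 2 `O=C1c2c(-c3ccccc3)cc(N3CCCC3)nc2OCCCN1Cc1cc(C(F)(F)F)cc(C(F)(F)F)c1` gives 13.8 nM, and compound 3 `O=C1c2c(-c3ccccc3F)cc(N3CCC(N4CCCC4)CC3)nc2OCCCN1Cc1cc(C(F)(F)F)cc(C(F)(F)F)c1` gives 0.207 nM, the lowest of the three numbers and well apart from both others. Compound 4 `O=C1c2c(-c3ccccc3Cl)cc(N3CCC(N4CCCC4)CC3)nc2OCCCN1Cc1cc(C(F)(F)F)cc(C(F)(F)F)c1` differs from compound 3 in one place: chloro in place of fluoro on an aromatic carbon. Going by the values given here, no measured pair shows this change, so its effect has to be estimated. A swap of fluoro for chloro at this place is expected to move the number little, if at all. The expected step from compound 3 to compound 4, a 1.2-fold higher number from compound 3 to compound 4 (0.08 log units; within the scatter), is thus within the usual scatter. Compound 4 is therefore estimated at 0.25 nM in this assay, with a range from 0.08 nM to 0.8 nM.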

Compound 4, antagonist equilibrium constant: 0.382 nM
Estimate against measurement, compound 4: 1.5-fold (0.18 log units) below; measured number inside the range.
By their numbers in this assay, from the lowest: compounds 3 and 4 (each within the scatter of the next); then compound 2; then compound 1.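

Going by these compounds alone, the first measured pair at this position gives a 1.8-fold higher number from compound 3 to compound 4 (0.27 log units; within the scatter) in this assay, so the 2-fluorophenyl and 2-chlorophenyl compounds cannot be told apart here. On this single pair, the place ortho to a large group accepts either halogen with no change beyond the scatter. Nothing measured here accounts for this result.

Still open, as far as these compounds go, is how a methoxy group, a nitrile or plain hydrogen at this place would read in this assay. Whether the same swap behaves alike with a different side chain is also unknown.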